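The compounds below may be only part of what the source reports. "The series", "measured", "known", "first", "only" and "open" are said of these compounds alone.

Compound 1 `COC(=O)[C@@]1(C)CCC=C2[C@@H]1CC[C@@H](C)[C@]2(C)Cc1c[nH]c2ccc(F)cc12` and compound 2 `COC(=O)[C@@]1(C)CCC=C2[C@@H]1CC[C@@H](C)[C@]2(C)Cc1c[nH]c2ccc(OC)cc12` share one core, while compound 3 `COC(=O)[C@@]1(C)CC[C@@H]2C3=C1CC[C@@H](C)[C@]3(C)C[C@@H]1c3cc(F)ccc3N[C@H]21` and compound 4 `COC(=O)[C@@]1(C)CC[C@@H]2C3=C1CC[C@@H](C)[C@]3(C)C[C@@H]1c3cc(OC)ccc3N[C@H]21` share another; the difference between the two cores is not broken down here. In a functional assay on SW1573 cells (Homo sapiens) for inhibition, read by sulforhodamine B assay, with a stated time of 48 h (a lower number here means a stronger inhibitor of growth, a higher number a weaker inhibitor of growth), compound 1 gives 7300 nM, and compound 2 gives 1300 nM. The change between them is methoxy in place of fluoro on an aromatic carbon, and it produced a 5.6-fold lower number from compound 1 to compound 2 (0.75 log units; beyond the scatter). In this assay compound 3 gives 27000 nM, the highest of the three numbers. Compound 4 carries methoxy in place of fluoro on an aromatic carbon, the same kind of change, though here the aromatic ring bearing it is part of a fused or bridged system of five rings rather than two. Resting on the earlier step of a 5.6-fold lower number from compound 1 to compound 2 (0.75 log units; beyond the scatter), and given that compound 3 gives 27000 nM, a step of a 4.9-fold lower number from compound 3 to compound 4 (0.69 log units; beyond the scatter) is expected. Compound 4 is therefore estimated at 5500 nM, with a likely range from 2500 nM to 13000 nM.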

Compound 4, concentration for 50% growth inhibition: 25000 nM
Compound 4: middle estimate off by 4.5-fold (0.66 log units), on the low side, outside the stated range (above it).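

On the core of compound 3, methoxy in place of fluoro gave a 1.1-fold lower number from compound 3 to compound 4 (0.03 log units; within the scatter) in this assay, so the drop in the number seen on the core of compound 1 did not carry over to this core. The two steps differ, so the effect of this change depends on the core it sits on in these two pairs: the same change on two cores in this assay, a 5.6-fold lower number (0.75 log units; beyond the scatter) from compound 1 to compound 2 and a 1.1-fold lower number (0.03 log units; within the scatter) from compound 3 to compound 4, 5.2-fold (0.72 log units) apart, beyond the scatter of two such steps These pairs do not show which part of the difference between the two cores is responsible, nor how any other change would carry from one core to the other.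

Going by these compounds, whether a hydroxyl or an amine on the same aromatic carbon would follow the pattern of methoxy on either core remains open. So does whether a carboxylic acid in place of the methyl ester would keep the two cores apart.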